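The source may report more compounds than this note shows. Statements on the series, on what has been measured and on what is new or still open speak of the compounds shown alone.

In a functional assay on A375P cells (Homo sapiens) for antiproliferative activity (on this read-out higher numbers stand for weaker inhibition and lower numbers for stronger inhibition), three compounds have been measured so far.

Compound 1 `CC(=O)Nc1cc(NC(=O)Nc2cc(Cl)cc(Cl)c2)ccc1C` gives 561 nM.
Compound 2 `CC(=O)Nc1cc(NC(=O)Nc2ccc(Cl)c(C(F)(F)F)c2)ccc1C` gives 1100 nM.
Compound 3 `CC(=O)Nc1cc(NC(=O)Nc2cc(F)cc(C(F)(F)F)c2)ccc1C` gives only > 30000 nM, which is a limit of the assay and not a number.

All three share the same core and differ only in the substituents on one of their rings. Compound 1 and compound 2 give numbers that lie within the usual scatter of each other, so neither can be called the stronger of the two. Compound 3 stands apart: its value is the limit of > 30000 nM in this assay, at which 1 of the 3 values shown sits, so all that can be said is that it inhibits growth far more weakly than compound 1 and compound 2.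

Compound 4 `Cc1ccc(NC(=O)Nc2cc(Cl)cc(Cl)c2)cc1NC(=O)c1ccccc1` is not yet measured. Relative to compound 1 it carries phenyl in place of methyl on a carbonyl carbon. Within the data shown here, no measured pair among the three compounds makes this kind of change, so there is no directly comparable step to lean on. The change replaces a small group by a larger aromatic one while leaving the counts of hydrogen-bond donors and acceptors unchanged, and I expect the step of a 1.4-fold lower number from compound 1 to compound 4 (0.15 log units; within the scatter) to be modest, most likely within the scatter or a small gain in potency. For compound 4 I therefore estimate 400 nM, with a range from 100 nM to 2000 nM.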

Compound 4, half-maximal inhibitory concentration: 259 nM
Compound 4: the middle estimate sits 1.5-fold (0.19 log units) above what was measured, and the stated range covers the measured number.
By their numbers in this assay, from the lowest: compound 4; then compounds 1 and 2 (each within the scatter of the next). At a limit, above all of these: compound 3.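

In this assay, the change from acetamido to benzamido gives a 2.2-fold lower number from compound 1 to compound 4 (0.34 log units; beyond the scatter), and since a lower number stands for stronger inhibition, this place on the shared core accepts a phenyl in place of methyl on a carbonyl carbon and the compound gains modestly in potency. Among these compounds, compounds 1, 2 and 3 all carry the same acetamido group and differ only in the substituents on one ring, so they could say nothing about this place; compound 4 is the first to show that a group of six heavy atoms with an aromatic ring can stand where a single methyl carbon stood. Nothing measured here accounts for why the benzamido compound gives the lower number.

On these data alone, this is a single step at a single place, so it stays open whether the aromatic ring matters or whether a saturated cyclohexyl ring or a longer chain such as butyl would serve as well. As far as these compounds go, it also stays open how far the phenyl itself can be extended, for instance with an amine or a carboxylic acid attached to it, and whether the same change would hold with the other substituents of compound 2.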